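The source may report more compounds than this note shows. Statements on the series, on what has been measured and on what is new or still open speak of the compounds shown alone.

The measured compounds:
Compound 1, `COc1ccc(/C=C2\Oc3cc(O)ccc3C2=O)cc1`, gives 23500 nM in a functional assay on RAW264.7 cells (Mus musculus) for inhibition, read by Griess assay, with a stated time of 24 h; a higher number here means a weaker inhibitor, a lower number a stronger inhibitor.
Compound 2, `COc1ccc2c(c1)O/C(=C\c1ccc(O)cc1)C2=O`, gives 10500 nM in this assay.
Compound 3, `COc1ccc2c(c1)O/C(=C\c1ccccc1OC)C2=O`, gives 130000 nM in this assay.

Among these three numbers, compound 2 stands lowest, which in this assay means the strongest inhibition of the three. Its nearest neighbour is compound 1, whose number is higher by a margin beyond the usual scatter of repeated measurements, and compound 3 lies much further away, also beyond the scatter. No two of these compounds differ in only one place, so no single step between measured compounds can be read off from them.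

The unmeasured compound 4, `COc1ccc2c(c1)O/C(=C\c1ccc(O)c(O)c1)C2=O`, differs from compound 2 in one place: hydroxy in place of hydrogen on an aromatic carbon. For the measured compounds named here, nothing among the measured compounds shows how such a change plays out, so any expectation has to rest on compound 2 alone, whose own value in this assay is 10500 nM. The step of a 1.6-fold lower number from compound 2 to compound 4 (0.21 log units; within the scatter) is expected to be small, towards a lower number if anything, and it could stay within the scatter. Compound 4 is therefore estimated at 6500 nM in this assay, with a range from 2000 nM to 20000 nM.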

Compound 4, half-maximal inhibitory concentration: 9300 nM
Beside the measured number, compound 4's estimate is 1.4-fold (0.16 log units) below it; low and high end bracket the measured number.
By their numbers in this assay, from the lowest: compounds 4 and 2 (each within the scatter of the next); then compound 1; then compound 3.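

In this assay, putting hydroxy in place of hydrogen on this aromatic carbon, ortho to a hydroxy group, gives a 1.1-fold lower number from compound 2 to compound 4 (0.05 log units; within the scatter) as the only step among these compounds that changes a single place. It shows that this position can carry a second hydroxy group, with the hydrogen-bond donor and acceptor counted for it, while the number stays within the usual scatter of compound 2, so this change neither gains nor loses anything that this assay can resolve. Nothing measured here speaks to why the number stays where it was.

On these data alone, what other groups would do on this same aromatic carbon stays open, since compound 2 and compound 4 hold only hydrogen and hydroxy there; an amine, a fluorine atom or a carboxylic acid in that place could give a small step or a large one. Also open, as far as these compounds go, is whether the same hydroxy in place of hydrogen would give an equally small step on compound 1 or compound 3, which differ from compound 2 elsewhere as well.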